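The source may hold more compounds than are shown below. What is called first, only, known or untested is meant among the compounds shown, and "the series" means these compounds.

Measured so far:
compound 1 `O=C(Nc1nc2ccccc2s1)c1cn(-c2ccccc2)nc1-c1ccc(Cl)cc1`, which in a functional assay on U-87MG ATCC cells for cytotoxicity against U-87 MG (Homo sapiens), read by MTT assay, with a stated time of 72 h (on this read-out higher numbers stand for weaker inhibition and lower numbers for stronger inhibition), gives 11500 nM;
compound 2 `Cc1ccc2nc(NC(=O)c3cn(-c4ccccc4)nc3-c3ccc(Cl)cc3)sc2c1`, which in this assay gives 33200 nM;
compound 3 `COc1ccc(-c2nn(-c3ccccc3)cc2C(=O)Nc2nc3ccccc3s2)cc1`, which in this assay gives 11500 nM.

Compound 3 sits level with compound 1, the pair sharing the lowest numbers of the three; the step between them is no change at the digits printed from compound 1 to compound 3 (within the scatter). Among the measured compounds shown here, the only step beyond the scatter runs to compound 2, which differs from compound 1 by a methyl on the fused ring and shows a 2.9-fold higher number from compound 1 to compound 2 (0.46 log units; beyond the scatter).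

Compound 4 `COc1ccc(-c2nn(-c3ccccc3)cc2C(=O)Nc2nc3ccc(C)cc3s2)cc1` is compound 3 with methyl in place of hydrogen on an aromatic carbon. For the measured compounds named here, that is the same change that separates compound 1 from compound 2, so the one relevant precedent is a modest rise. A rise of similar size is expected for compound 4 in this assay: an estimated 2.6-fold higher number from compound 3 to compound 4 (0.42 log units; beyond the scatter), giving 30000 nM with a range from 14000 nM to 65000 nM.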

Compound 4, half-maximal inhibitory concentration: > 50000 nM
Compound 4: only a limit was reported; the forecaster's own chance of this, stated with the estimate: 10%; middle value at least 1.6-fold (0.22 log units) from the limit.
By their numbers in this assay, from the lowest: compounds 1 and 3 (each within the scatter of the next); then compound 2. At a limit, above all of these: compound 4.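

In this assay, the methyl change raises the number on a second core, with an at least 4.3-fold higher number from compound 3 to compound 4 (0.63 log units; beyond the scatter), so the rise is no longer seen on the chloro compounds alone: the same change on two cores in this assay, a 2.9-fold higher number (0.46 log units; beyond the scatter) from compound 1 to compound 2 and an at least 4.3-fold higher number (0.63 log units; beyond the scatter) from compound 3 to compound 4; the limit leaves it open whether they differ For compound 4, > 50000 nM is a limit of the assay, not a number. Methoxy in place of chloro, silent without the methyl, now gives an at least 1.5-fold higher number from compound 2 to compound 4 (0.17 log units; that floor lies within the scatter), and that floor cannot show whether this swap matters once the methyl is present: the same change on two cores in this assay, no change at the digits printed (within the scatter) from compound 1 to compound 3 and an at least 1.5-fold higher number (0.17 log units; that floor lies within the scatter) from compound 2 to compound 4; the limit leaves it open whether they differ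

As far as these compounds go, only hydrogen and methyl appear at this position, so it remains open how an amine, a carboxylic acid or a longer chain there would behave.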